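Acylurea thiazole hydrazones: trifluoromethyl step on the benzylidene ring

The compounds below may be only part of what the source reports. "The series", "measured", "known", "first", "only" and "open" are said of these compounds alone.

Measured compounds:
compound 1 `CN(C(=O)NC(=O)c1ccc(Cl)cc1Cl)c1nc(C(F)(F)F)c(C(=O)N/N=C/c2cccc(C(F)(F)F)c2)s1` — 6.11 ug/mL
compound 2 `CN(C(=O)NC(=O)c1ccc(Cl)cc1Cl)c1nc(C(F)(F)F)c(C(=O)N/N=C/c2cc(C(F)(F)F)cc(C(F)(F)F)c2)s1` — > 100 ug/mL
compound 3 `Cc1nc(N(C)C(=O)NC(=O)c2c(F)cccc2F)sc1C(=O)N/N=C/c1cccc(C(F)(F)F)c1` — 32.7 ug/mL

In a functional assay on BCG823 cells (Homo sapiens) for inhibition, read by MTT assay, with a stated time of 72 h (a higher number here means a weaker inhibitor, a lower number a stronger inhibitor), compound 1 gives 6.11 ug/mL. Compound 2 reaches only the assay limit, > 100 ug/mL, which is a limit and not a number (the limit of > 100 ug/mL in this assay, at which 1 of the 3 values shown sits). The change between them is trifluoromethyl in place of hydrogen on an aromatic carbon, and it makes an at least 16-fold higher number from compound 1 to compound 2 (1.21 log units; beyond the scatter).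

Compound 3 gives 32.7 ug/mL in this assay, the higher of the two numbers, with compound 1 as its nearest neighbour. The difference between the core of compound 3 and the core of compound 1 is not broken down here.

Compound 4 `Cc1nc(N(C)C(=O)NC(=O)c2c(F)cccc2F)sc1C(=O)N/N=C/c1cc(C(F)(F)F)cc(C(F)(F)F)c1` is not yet measured. It differs from compound 3 by trifluoromethyl in place of hydrogen on an aromatic carbon, the same change that separates compound 1 from compound 2, at the same place on the ring. Starting from the weaker compound 3, the step from compound 3 to compound 4 is expected to be a 7.6-fold higher number from compound 3 to compound 4 (0.88 log units; beyond the scatter), resting on the earlier step of an at least 16-fold higher number from compound 1 to compound 2 (1.21 log units; beyond the scatter). Compound 4 is therefore expected to give about 250 ug/mL in this assay, most likely reported as a limit, within 60 ug/mL to 1500 ug/mL.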

Compound 4, half-maximal inhibitory concentration: 14.1 ug/mL
Compound 4: the middle estimate sits 18-fold (1.25 log units) above what was measured; measured number outside the range, below it.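

In this assay, trifluoromethyl in place of hydrogen on an aromatic carbon gives a 2.3-fold lower number from compound 3 to compound 4 (0.37 log units; beyond the scatter), so the earlier result on the core of compound 1 did not carry over to the core of compound 3 in either direction or size: the same change on two cores in this assay, an at least 16-fold higher number (1.21 log units; beyond the scatter) from compound 1 to compound 2 and a 2.3-fold lower number (0.37 log units; beyond the scatter) from compound 3 to compound 4, at least 37-fold (1.57 log units) apart, beyond the scatter of two such steps Compound 2 stands at > 100 ug/mL, which is a limit of the assay and not a number. These two pairs show that the outcome of this change is not transferable between these two cores, but they set no rule for the series and do not show which difference between the cores separates the results.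

Still open, from the compounds shown here alone, is how the same step behaves on a core that carries only one of those differences, such as the acylurea aryl group of compound 3 joined to the remainder of compound 1. Also open, going by these compounds, is whether another group at the same place on the ring, such as an amine or a carboxylic acid, would follow either step.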